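The source may report more compounds than this note shows. Statements on the series, on what has been measured and on what is new or still open speak of the compounds shown alone.

Compound 1 `Cc1cc(C)c(OC2CC2)c(C)c1NC(=O)c1sccc1S(=O)(=O)Nc1onc(C)c1Cl`: 12300 nM
Compound 2 `Cc1cc(C)c(S(N)(=O)=O)c(C)c1NC(=O)c1sccc1S(=O)(=O)Nc1onc(C)c1Cl`: 5590 nM

In an in vivo ADME assay on the whole organism (plasma) for pharmacokinetics, with Rattus norvegicus as the target, at a dose of 50 mg/kg by the oral route (a lower number here means less compound in the circulation, a higher number more compound in the circulation at the dose given), compound 2 has the lower of the two numbers. Next is compound 3 `Cc1cc(C)c(NC(=O)c2sccc2S(=O)(=O)Nc2onc(C)c2Cl)c(C)c1O`, with hydroxy in place of sulfamoyl on an aromatic carbon. Within the data shown here, the one measured step bearing on this is a 2.2-fold lower number from compound 1 to compound 2 (0.34 log units; beyond the scatter), a modest exchange that also falls on an aromatic carbon. Hydroxy has no measured precedent among these compounds, so no direction can be firmly assigned, and no change beyond the scatter is expected in this assay. The estimated step is a 1.4-fold lower number from compound 2 to compound 3 (0.15 log units; within the scatter). For compound 3, the expected value is 4000 nM, with an estimated range of 1200 nM to 13000 nM.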

Compound 3, maximal plasma concentration: 106000 nM
The estimate for compound 3 lay 27-fold (1.42 log units) below the measured number; the measured number lies above the stated range.
By their numbers in this assay, from the lowest: compound 2; then compound 1; then compound 3.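

At this position on the aromatic ring, the group on the ring carbon can shift this assay far more than the step between compounds 1 and 2 showed: the result is a 19-fold higher number from compound 2 to compound 3 (1.28 log units; beyond the scatter). Removing only the cyclopropyl from the oxygen also gives an 8.6-fold higher number from compound 1 to compound 3 (0.94 log units; beyond the scatter), so the free hydroxy stands above both the sulfamoyl and cyclopropyloxy groups. No measured information here accounts for this rise.

Still open, as far as these compounds go, is whether methoxy, with a smaller group on that oxygen, stays near the hydroxy or the cyclopropyloxy number. From the compounds shown here alone, an amine at the same carbon is equally open.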